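A few compounds are considered here, and "the series" means these few. Any claim that something is new, unique, unknown or untested is made for them only; others in the source may bear on it.

Compound 1 `O=C(Nc1nc(-c2cc3ccccc3o2)cs1)Nc1ccccc1F` is the starting point of this account. In a physicochemical assay, with a stated time of 6 min (a lower number here means a stronger inhibitor, a higher number a weaker inhibitor), compound 1 gives 2630 nM, the lowest of the two numbers recorded, while compound 2 `O=C(Nc1cccc([N+](=O)[O-])c1)Nc1nc(-c2cc3cc(Br)ccc3o2)cs1` gives 159000 nM. Compound 3 `O=C(Nc1nc(-c2cc3cc(Br)ccc3o2)cs1)Nc1ccccc1F` reaches the limit of > 200000 nM in this assay, at which 1 of the 3 values shown sits, and so in this assay it gives only > 200000 nM, a limit rather than a number. The two measured steps are an at least 76-fold higher number from compound 1 to compound 3 (1.88 log units; beyond the scatter) and an at least 1.2-fold higher number from compound 2 to compound 3 (0.09 log units; that floor lies within the scatter). Compound 4 `O=C(Nc1nc(-c2cc3ccccc3o2)cs1)Nc1ccccc1[N+](=O)[O-]` differs from compound 1 by nitro in place of fluoro on an aromatic carbon. Only the exchange of 2-fluorophenyl for 3-nitrophenyl involves a nitro group, and its floor lies within the scatter, so it gives no direction; the bromo step does not bear on this change. The step expected for compound 4 is a 1.5-fold higher number from compound 1 to compound 4 (0.18 log units; within the scatter). The estimate for compound 4 in this assay is 4000 nM, within 1000 nM to 20000 nM.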

Compound 4, half-maximal inhibitory concentration: 20300 nM
Beside the measured number, compound 4's estimate is 5.1-fold (0.71 log units) below it, outside the stated range (above it).
By their numbers in this assay, from the lowest: compound 1; then compound 4; then compound 2. At a limit, above all of these: compound 3.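

Nitro in place of fluoro, on the aromatic carbon ortho to a large group, gives a 7.7-fold higher number from compound 1 to compound 4 (0.89 log units; beyond the scatter) in this assay and so shows that this position does not tolerate every group alike. Among these compounds, the earlier compounds gave no direction for a nitro group, and this is the first readable step for one, running toward weaker inhibition. Nothing available here accounts for the size of this step.

Going by these compounds, whether an amine or a carboxylic acid at this position would give a lower number than fluoro remains open.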